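Bridged Diamine Replaces Oxetanyl Piperazine on an Inactive Core

The source may report more compounds than this note shows. Statements on the series, on what has been measured and on what is new or still open speak of the compounds shown alone.

Compound 1 `CN(C[C@H]1Cc2c(cccc2N2CCN(C3COC3)CC2)CN1)[C@H]1CCCc2cccnc21` was tested in a functional assay on CCRF-CEM cells for agonist activity at C-X-C chemokine receptor type 4 (Homo sapiens), read by calcium flux, with a stated time of 25 min; a lower number here means that less compound is needed, a higher number that more compound is needed for the effect. For compound 1 the result is only a limit of the assay, > 30000 nM, and not a number. Compound 2 `CC(C)N(C[C@H]1Cc2c(cccc2N2CCNCC2)CN1)[C@H]1CCCc2cccnc21` likewise gives only a limit in this assay, > 30000 nM. Compound 1 therefore stands at the limit of > 30000 nM in this assay, at which 2 of the 2 values shown sit, with nothing to set it apart from compound 2. Going by the values given here, no step between measured compounds can be computed here.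

Compound 3 `CN(C[C@H]1Cc2c(cccc2N2C[C@H]3C[C@@H]2CN3)CN1)[C@H]1CCCc2cccnc21` has not yet been measured. It differs from compound 1 in one place: a group of 7 heavy atoms (5 carbon, 2 nitrogen; 2 five-membered non-aromatic rings with 1 hetero atom each) in place of a group of 10 heavy atoms (7 carbon, 2 nitrogen, 1 oxygen; one four-membered non-aromatic ring with 1 hetero atom, one six-membered non-aromatic ring with 2 hetero atoms), on an aromatic carbon. The two measured compounds, both at the limit, give no direction for this change.

Compound 3 is expected to give 30000 nM, with a range from 10000 nM to 100000 nM, and most likely to be reported again only as a limit. The estimated step of a number no higher from compound 1 to compound 3 (the limit leaves the size open) means no change beyond the scatter is expected.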

Compound 3, half-maximal effective concentration: > 30000 nM
Compound 3 was reported as a limit; the forecaster's own chance of this, stated with the estimate: 80%; the middle value sits exactly at the limit.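

No step from compound 1 to compound 3 can be read, because both results are limits of the assay and not numbers: the limit of > 30000 nM in this assay, at which 3 of the 3 values shown sit.

The compounds shown leave open how the two groups compare, and whether any compound on this core gives a measurable response in this assay.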